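From Methyl to Phenyl on the Core of Compound 2

The source may hold more compounds than are shown below. What is called first, only, known or untested is meant among the compounds shown, and "the series" means these compounds.

Of the compounds shown here, two have been measured so far in a functional assay on THP-1 cells (Homo sapiens) for inhibition, read by ELISA, tested at 10 uM; a lower number here means less inhibition, a higher number more inhibition at the concentration tested (going by the name of the read-out). Compound 1 `COc1ccc(-c2nn(-c3ccccc3)c3ncc(CCCO)cc23)cc1` gives 36%. Compound 2 `Cc1ccc(O)c(C(=O)c2ccc3onc(C)c3c2)c1` gives 58% in this assay, the higher of the two numbers, and its gap to compound 1 lies beyond the usual scatter of repeated measurements.

Compound 3 `Cc1ccc(O)c(C(=O)c2ccc3onc(-c4ccccc4)c3c2)c1` has not yet been measured in this assay. It differs from compound 2 in one place: phenyl in place of methyl on an aromatic carbon. For the measured compounds named here, no pair of measured compounds differing in one place is available, so no measured step shows how a change of this kind plays out in this assay; the two numbers known only show that the core shared by compound 2 and compound 3 reaches a higher inhibition than compound 1 does.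

Without such a precedent, the expected step in this assay is a number 3 percentage points lower from compound 2 to compound 3 (within the scatter), judged to be small or none beyond the scatter, with either direction possible. The estimate for compound 3 in this assay is therefore 55%, with a range from 25% to 85%.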

Compound 3, a percentage reported as inhibition, at one concentration (the size of the read-out at that concentration, not a potency): 63%
The estimate for compound 3 lay 8 percentage points below the measured number, within the range that was stated.
By their numbers in this assay, from the lowest: compound 1; then compounds 2 and 3 (each within the scatter of the next).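

In this assay, for the compounds shown here, this is the first measured step on this core: phenyl in place of methyl, on an aromatic carbon of the five-membered aromatic ring next to the ring nitrogen, gives a number 5 percentage points higher from compound 2 to compound 3 (within the scatter) and not a change that can be told apart from repeat-to-repeat variation. The position therefore holds a group of 6 heavy atoms with a ring of its own in place of a group of 1 heavy atom, and the level of inhibition at the concentration tested is kept within the scatter. Nothing measured here speaks to the reason for this outcome.

The compounds shown leave open what happens at this carbon with an amine, a carboxylic acid or a longer chain such as propyl, since methyl and phenyl, both made of carbon and hydrogen only, are the sole groups seen there. On these data alone, each number is also a percentage at one concentration and not a potency, so how these two compounds compare at other concentrations remains open.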